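Ethoxy on the aromatic ring of compound 3

This account rests on a few compounds, and the source may have more. Where it says the series, first, only, none or still open, it means among the compounds named here.

Measured so far in a functional assay on the whole organism (strain Sprague-Dawley) for inhibition, with Rattus norvegicus as the target, with a stated time of 10 min; a higher number here means that more compound is needed for the effect, a lower number that less compound is needed
compound 1 `COc1ccc(-c2ncc(C(=O)O)c(=O)[nH]2)cc1` gives > 5 mg/kg (a limit)
compound 2 `Cn1c(-c2ccccc2)ncc(C(=O)O)c1=O` gives 50 mg/kg
compound 3 `CCOC(=O)c1cnc(-c2ccccc2)n(C)c1=O` gives > 5 mg/kg (a limit)

Compound 3 stands only at a limit (> 5 mg/kg), so no number fixes its place. Its reference point is the limit of > 5 mg/kg in this assay, at which 2 of the 3 values shown sit, and nothing sharper. Within the data shown here, the only number belongs to compound 2 (50 mg/kg).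

The next compound, compound 4 `CCOC(=O)c1cnc(-c2ccccc2OCC)n(C)c1=O`, has ethoxy in place of hydrogen on an aromatic carbon, ortho to a large group (ethoxy in place of hydrogen on an aromatic carbon). Among the measured compounds shown here, the series holds no measured step at this place on the ring. For the measured compounds named here, the one step available is a step that the limit leaves unreadable from compound 2 to compound 3 and it concerns another part of the molecule, so it gives neither a size nor a direction for this change.

No firm shift in this assay can therefore be expected in either direction, and compound 4 may well be reported as a limit too. The expected change is a step that the limit leaves unreadable from compound 3 to compound 4 and this estimate is loose. For compound 4 the estimated dose is 6 mg/kg with an expected range from 1.5 mg/kg to 30 mg/kg.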

Compound 4, dose for 50% inhibition: > 40 mg/kg
Compound 4 ended at the assay's limit; the forecaster's own chance of this, stated with the estimate: 55%; middle value at least 6.6-fold (0.82 log units) from the limit.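

In this assay, among these compounds, compound 3 and compound 4 are both reported only as limits, so no step between them can be read. The compounds shown leave open whether ethoxy in place of hydrogen on the aromatic carbon changes the dose needed for the effect, and if so, in which direction and by how much.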